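A few compounds are considered here, and "the series" means these few. Any claim that something is new, unique, unknown or untested is made for them only; others in the source may bear on it.

Measured so far in an ADME assay on CCRF-HSB-2 cells (Homo sapiens) for cytotoxicity, with a stated time of 7 days (on this read-out higher numbers stand for lower toxicity in this test and lower numbers for higher toxicity in this test), where each value is a limit of the assay and not a number:
- compound 1 `Nc1nc(NC2CC2)c2ncn(/C=C3/CC3(CO)CO)c2n1`: > 20000 nM
- compound 2 `CCCCCOc1nc(N)nc2c1ncn2/C=C1/CC1(CO)CO`: > 20000 nM
- compound 3 `CC(C)Nc1nc(N)nc2c1ncn2/C=C1/CC1(CO)CO`: > 20000 nM

Compound 2 thus stands at a limit only, and so do the two other values shown, all at the limit of > 20000 nM in this assay, at which 3 of the 3 values shown sit. The step to compound 4 `Nc1nc(SCc2ccccc2)c2ncn(/C=C3/CC3(CO)CO)c2n1` changes the shared core at one place: benzylsulfanyl in place of pentyloxy on an aromatic carbon. The steps that touch compound 2, a step that the two limits leave unreadable from compound 1 to compound 2 and a step that the two limits leave unreadable from compound 2 to compound 3, are unreadable in size, so they neither point to a direction nor rule one out. The expected step is therefore a step that the limit leaves unreadable from compound 2 to compound 4, meaning no change beyond the scatter. For compound 4 the estimate is 30000 nM, with a range from 10000 nM to 100000 nM.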

Compound 4, half-maximal cytotoxic concentration: > 100000 nM
Compound 4: no number, only a limit; the forecaster's own chance of this, stated with the estimate: 85%; at least 3.3-fold (0.52 log units) between middle value and limit.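

Compound 4 stands only at a limit of the assay, as do compound 1, compound 2 and compound 3, so its steps from those three cannot be read in size. The compounds shown leave open what concentration of any of them would be toxic in this assay.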